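The compounds below may be only part of what the source reports. "The series", "measured", "known", "first", "only" and "open" are said of these compounds alone.

Compound 3 `CC#CC(CC(=O)O)c1ccc(OCc2ccc(C(=O)N3CCN(c4cccnc4)CC3)s2)cc1` stands highest of the two numbers shown in a functional assay on HEK293 cells for agonist activity at Free fatty acid receptor 1 (Homo sapiens), read by fluorescence and calcium flux (on this read-out higher numbers stand for an effect only at larger amounts of compound and lower numbers for an effect already at smaller amounts), where compound 3 gives 1140 nM. The nearest is compound 1 `CC#CC(CC(=O)O)c1ccc(OCc2ccc(C(=O)N3CCN(C4CCCCC4)CC3)s2)cc1`, which in this assay gives 820 nM. Compound 2 `CC#CC(CC(=O)O)c1ccc(OCc2ccc(C(=O)N3CCN(c4ccncc4)CC3)s2)cc1` reaches only the limit of this assay, > 5000 nM. The change a 1.4-fold higher number from compound 1 to compound 3 (0.14 log units; within the scatter) lies within the scatter, whereas both an at least 6.0-fold higher number from compound 1 to compound 2 (0.78 log units; beyond the scatter) and an at least 4.3-fold lower number from compound 2 to compound 3 (0.64 log units; beyond the scatter) are steps beyond it. Compound 4 `CC#CC(CC(=O)O)c1ccc(OCc2ccc(C(=O)N3CCN(c4ccc(OC)cc4)CC3)s2)cc1` carries 4-methoxyphenyl in place of pyridin-3-yl on an amine nitrogen in a ring. Going by the values given here, no measured step involves an aromatic ring of carbon only, so the change is weakly informed by these three compounds; the step of a 1.4-fold higher number from compound 1 to compound 3 (0.14 log units; within the scatter) suggests that a step of a 1.3-fold higher number from compound 3 to compound 4 (0.12 log units; within the scatter) with no clear direction is the expected outcome. Compound 4 is therefore estimated at 1500 nM, between 400 nM and 6000 nM.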

Compound 4, half-maximal effective concentration: 289 nM
For compound 4 the middle estimate is 5.2-fold (0.72 log units) above the measured one; the measured number lies below the stated range.
By their numbers in this assay, from the lowest: compound 4; then compounds 1 and 3 (each within the scatter of the next). At a limit, above all of these: compound 2.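

Going by these compounds alone, on the amine nitrogen in the ring, 4-methoxyphenyl gives the first lower number beyond the scatter in place of cyclohexyl in this assay: a 2.8-fold lower number from compound 1 to compound 4 (0.45 log units; beyond the scatter). The aromatic ring of carbon only also improves on a pyridine ring, with a 3.9-fold lower number from compound 3 to compound 4 (0.60 log units; beyond the scatter). Compound 2 stands at a limit, so an at least 17-fold lower number from compound 2 to compound 4 (1.23 log units; beyond the scatter) is only a bound: the limit of > 5000 nM in this assay, at which 1 of the 4 values shown sits.

The compounds shown do not separate the methoxy group from the ring of carbon only. Going by these compounds, how an unsubstituted phenyl or a 4-chlorophenyl would read at this position remains open.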